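Moving a tert-butyl group on the benzyl ring

A few compounds are considered here, and "the series" means these few. Any claim that something is new, unique, unknown or untested is made for them only; others in the source may bear on it.

Measured so far:
compound 1 `COC(=O)c1ccc(NCc2cncn2Cc2ccccc2)cc1-c1ccccc1`: > 1000 nM
compound 2 `COC(=O)c1ccc(NCc2cncn2Cc2ccc(C(C)(C)C)cc2)cc1-c1ccccc1`: "not determined" (no result reported)

In a toxicity assay on NIH3T3 cells (Mus musculus) for cytotoxicity, read by resazurin assay (on this read-out higher numbers stand for an effect only at larger amounts of compound and lower numbers for an effect already at smaller amounts), compound 1 gives > 1000 nM, and this is a limit of the assay, not a number. Compound 2 has no place of its own on the scale, as its entry reads "not determined" (no result reported). Within the data shown here, the only reference point for compound 2 is therefore compound 1, with the limit of > 1000 nM in this assay, at which 1 of the 2 values shown sits.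

Compound 3 `COC(=O)c1ccc(NCc2cncn2Cc2cccc(C(C)(C)C)c2)cc1-c1ccccc1` has still to be measured in this assay. The structural change is 3-(tert-butyl)phenyl in place of 4-(tert-butyl)phenyl on a saturated chain carbon bound to an aromatic nitrogen, with 3-(tert-butyl)phenyl in place of 4-(tert-butyl)phenyl on a saturated chain carbon bound to an aromatic nitrogen. Among the measured compounds shown here, the two structures hold the same atoms, and no measured step exists to show what such a change does. No step beyond the usual scatter is expected in this assay, in either direction. The expectation for compound 3 therefore leans on compound 1, whose reading of > 1000 nM is again a limit. For compound 3 the half-maximal effective concentration is estimated at about 8000 nM, with an expected range from 2000 nM to 30000 nM.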

Compound 3, half-maximal effective concentration: > 1000 nM
Compound 3 ended at the assay's limit; the forecaster's own chance of this, stated with the estimate: 65%; the middle value lies beyond the limit too.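

In this assay compound 3 gives > 1000 nM, which is a limit and not a number. No step can be read from compound 1 to compound 3, because both readings are limits: the limit of > 1000 nM in this assay, at which 2 of the 3 values shown sit.

The compounds shown leave open how far either compound lies beyond that limit and what 3-(tert-butyl)phenyl in place of 4-(tert-butyl)phenyl does in this assay.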